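This account rests on a few compounds, and the source may have more. Where it says the series, first, only, none or still open, it means among the compounds named here.

Two members of the series have been run in a functional assay on U-87MG ATCC cells for antiproliferative activity against U-87 MG (Homo sapiens), read by MTT assay, with a stated time of 72 h; on this read-out lower numbers stand for stronger inhibition and higher numbers for weaker inhibition. Compound 1 `Cc1nn(C)c(Oc2ccc(Cl)cc2)c1/C=N\CCCCCOc1cc2oc(=O)cc(C)c2cc1Cl` gives 18700 nM in this assay. Compound 2 `Cc1nn(C)c(Oc2ccc(F)cc2F)c1/C=N\CCCCCCOc1cc2oc(=O)cc(C)c2cc1Cl` returns only a limit of the assay in this assay, > 25000 nM, so no number stands for it. The weak end of the read-out is marked by the limit of > 25000 nM in this assay, at which 1 of the 2 values shown sits. Compound 3 `Cc1nn(C)c(Oc2ccc(OC(F)(F)F)cc2)c1/C=N\CCCCCCOc1cc2oc(=O)cc(C)c2cc1Cl` is the next member to be measured in this assay; relative to compound 2 it carries 4-(trifluoromethoxy)phenyl in place of 2,4-difluorophenyl on an oxygen on an aromatic ring. No measured pair in the set isolates this change, so the step it brings cannot be read from the numbers shown. The expectation rests on compound 2 standing at > 25000 nM in this assay and on compound 1 giving 18700 nM there. Compound 3 is expected to stay in the same weak region, with a step no larger than the scatter, estimated as an at least 1.1-fold lower number from compound 2 to compound 3 (0.05 log units; that floor lies within the scatter). Compound 3 is thus estimated at 22000 nM, within 10000 nM to 50000 nM, with a fair chance that only a limit is reported again.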

Compound 3, half-maximal inhibitory concentration: 9620 nM
Compound 3: middle estimate off by 2.3-fold (0.36 log units), on the high side; the whole stated range lies above it.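

In this assay, the group on an oxygen on an aromatic ring proves able to move the read-out with the rest of the structure unchanged: 4-(trifluoromethoxy)phenyl in place of 2,4-difluorophenyl gives an at least 2.5-fold lower number from compound 2 to compound 3 (0.41 log units; beyond the scatter). The value of compound 2, > 25000 nM, is a limit of the assay and not a number. The step is therefore a lower bound only, and its true size stays unknown, with one value still at the weak end of the read-out: the limit of > 25000 nM in this assay, at which 1 of the 3 values shown sits.

Among these compounds, compound 1 differs from compound 2 and from compound 3 in more than one place, so no steps to it can be read and the role of the linking chain stays open. A plain phenyl or a 4-methoxyphenyl on the same oxygen would test whether the trifluoromethoxy group itself carries the step.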